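A few compounds are considered here, and "the series" means these few. Any claim that something is new, unique, unknown or untested is made for them only; others in the source may bear on it.

In a functional assay on HepG2 cells (Homo sapiens) for inhibition, read by MTT assay, with a stated time of 72 h (a higher number here means a weaker inhibitor, a lower number a stronger inhibitor), three compounds sharing one core have been measured. Compound 1 `CC(C)c1ccc(NC(=O)C2CCN(C/C=C/c3ccccc3)CC2)cc1`, with isopropyl, gives 12200 nM, compound 2 `CCCCc1ccc(NC(=O)C2CCN(C/C=C/c3ccccc3)CC2)cc1`, with butyl, gives 4320 nM, and compound 3 `CCCCCc1ccc(NC(=O)C2CCN(C/C=C/c3ccccc3)CC2)cc1`, with pentyl, gives 2890 nM. The gap to its nearest neighbour is a 1.5-fold lower number from compound 2 to compound 3 (0.17 log units; within the scatter), so these two cannot be separated, while the gap to the furthest is a 4.2-fold lower number from compound 1 to compound 3 (0.63 log units; beyond the scatter). Compound 4 `COc1ccc(NC(=O)C2CCN(C/C=C/c3ccccc3)CC2)cc1` follows from methoxy in place of pentyl on an aromatic carbon. Going by the values given here, no measured compound carries methoxy, so the evidence is indirect. Among the compounds with values here, the steps that bear on it are the modest ones at this same place, a 2.8-fold lower number from compound 1 to compound 2 (0.45 log units; beyond the scatter) and the one already given for pentyl over isopropyl. Removing pentyl is therefore expected to reverse a step of similar modest size, towards the higher number of compound 1 at 12200 nM. The expected change is a 4.5-fold higher number from compound 3 to compound 4 (0.65 log units; beyond the scatter). For compound 4 the estimated value is 13000 nM, with an expected range of 5000 nM to 35000 nM.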

Compound 4, half-maximal inhibitory concentration: 88800 nM
Beside the measured number, compound 4's estimate is 6.8-fold (0.83 log units) below it; the measured number lies above the stated range.
By their numbers in this assay, from the lowest: compounds 3 and 2 (each within the scatter of the next); then compound 1; then compound 4.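

In this assay, the change to methoxy weighs far more than any step among the alkyl groups: replacing pentyl gives a 31-fold higher number from compound 3 to compound 4 (1.49 log units; beyond the scatter), and replacing butyl gives a 21-fold higher number from compound 2 to compound 4 (1.31 log units; beyond the scatter). Isopropyl, the weakest of the earlier compounds, does not mark the upper end at this position either, since methoxy in its place gives a 7.3-fold higher number from compound 1 to compound 4 (0.86 log units; beyond the scatter). The numbers at this aromatic carbon therefore span a much wider range than the three alkyl compounds showed, and compound 4, the only one with an oxygen in this group, is the weakest of the four. Nothing available explains the size of this change.

The compounds shown leave open whether the oxygen or the shorter chain accounts for the step. An ethyl group, a butoxy chain or a hexyl chain at this place would help to separate the two.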